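Cytotoxicity Limits Across Three Measured Compounds and a Fourth

The source may hold more compounds than are shown below. What is called first, only, known or untested is meant among the compounds shown, and "the series" means these compounds.

Compound 1 `CC(C)N(Cc1cccc(OCCCCCC(=O)O)c1)C(=O)c1ccc(-c2cccc3ccccc23)cc1`: in an ADME assay on HEK293 cells (Homo sapiens) for cytotoxicity, read by CellTiter-Glo and resazurin assay, with a stated time of 72 h (a lower number here means that less compound is needed, a higher number that more compound is needed for the effect), compound 1 gives > 26000 nM, a limit of the assay and not a number.
Compound 2 `CC(C)N(Cc1cccc(OCCCCCC(=O)O)c1)C(=O)c1ccc(-c2cccc(F)c2)cc1`: in this assay compound 2 gives > 26000 nM, again a limit.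
Compound 3 `CCOC(=O)CCCCCOc1cccc(CN(C(=O)c2ccc(-c3cccc4ccccc34)cc2)C(C)C)c1`: in this assay compound 3 gives > 26000 nM, also a limit.

Compound 3 therefore stands at the same limit as the two other compounds; none of the three reports a number, and the limit of > 26000 nM in this assay, at which 3 of the 3 values shown sit, describes where all of them sit. The two measured steps are a step that the two limits leave unreadable from compound 1 to compound 2 and a step that the two limits leave unreadable from compound 1 to compound 3, and neither can be read in size or direction because both ends rest on limits.

Compound 4 `CCOC(=O)CCCCCOc1cccc(CN(C(=O)c2ccc(-c3ccc(C(C)=O)s3)cc2)C(C)C)c1` differs from compound 3 by 5-acetylthiophen-2-yl in place of naphthalen-1-yl on an aromatic carbon. The step from compound 1 to compound 2 is the one that bears most directly on this change, since it also exchanges the naphthalen-1-yl for another aromatic group on the same aromatic carbon, yet it was unreadable. No readable step in this assay therefore informs the expectation, and the step of a number no higher from compound 3 to compound 4 (the limit leaves the size open) is expected to be none beyond the scatter, with compound 4 most likely reporting a limit as well. The estimate for compound 4 in this assay is 26000 nM, between 10000 nM and 60000 nM.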

Compound 4, half-maximal effective concentration: > 26000 nM
Compound 4: a limit, no number; the forecaster's own chance of this, stated with the estimate: 80%; the middle value sits exactly at the limit.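

The step between compound 3 and compound 4 cannot be read in size or direction, because both compounds rest on the same limit: the limit of > 26000 nM in this assay, at which 4 of the 4 values shown sit.

The compounds shown leave open at what concentration any of them would reach the half-maximal effect in this assay, and whether 5-acetylthiophen-2-yl in place of naphthalen-1-yl changes that concentration.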